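Taking the furan amide off compound 2

The source may hold more compounds than are shown below. What is called first, only, known or untested is meant among the compounds shown, and "the series" means these compounds.

In a functional assay on KB cells (Homo sapiens) for cytotoxicity (a lower number here means a stronger inhibitor, a higher number a weaker inhibitor), compound 1 `COc1ccc(S(=O)(=O)N2CCc3cccc(NC(C)=O)c32)cc1` gives 89 nM and compound 2 `COc1ccc(S(=O)(=O)N2CCc3cccc(NC(=O)c4ccco4)c32)cc1` gives 9.6 nM, so compound 2 holds the lower of the two numbers. Compound 3 `COc1ccc(S(=O)(=O)N2CCc3cccc(N)c32)cc1` has not yet been measured. It differs from compound 2 in one place: hydrogen in place of (furan-2-yl)carbonyl on a nitrogen on an aromatic ring. Put simply, hydrogen stands in place of (furan-2-yl)carbonyl on a nitrogen on an aromatic ring, which leaves a plain amino group. Within the data shown here, only one measured step bears on this change: putting furan-2-yl in place of methyl on a carbonyl carbon gave a 9.3-fold lower number from compound 1 to compound 2 (0.97 log units; beyond the scatter). Among the measured compounds shown here, that step touches only part of the group lost here, and no measured compound carries the plain amino group, so the evidence is indirect. A somewhat larger step towards a higher number is therefore expected in this assay, estimated as a 21-fold higher number from compound 2 to compound 3 (1.32 log units; beyond the scatter). Compound 3 is expected at about 200 nM, within an estimated range of 40 nM to 1500 nM.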

Compound 3, half-maximal inhibitory concentration: 2800 nM
Estimate against measurement, compound 3: 14-fold (1.15 log units) below, outside the stated range (above it).
By their numbers in this assay, from the lowest: compound 2; then compound 1; then compound 3.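

In this assay, cutting the (furan-2-yl)carbonyl group back to a plain amino group gives a 290-fold higher number from compound 2 to compound 3 (2.46 log units; beyond the scatter), while removing the acetyl group gives a 31-fold higher number from compound 1 to compound 3 (1.50 log units; beyond the scatter). Among these compounds, the earlier pair compared only two acyl groups, whereas compound 3 shows that even the acetyl-bearing compound 1 has a lower number than the free amine, and that furan-2-yl lowers it further. No measurement shown here explains why the number rises when either acyl group is lost. Going by these compounds, it remains open whether the carbonyl is needed at all, as a methanesulfonyl group or a methylamino group on this nitrogen would test. On these data alone, it is also open whether the furan ring itself matters, or whether a phenyl or thiophene ring on the carbonyl carbon would serve as well.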